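The compounds below may be only part of what the source reports. "The series", "measured", "known", "first", "only" and "open" are said of these compounds alone.

Compound 1 `O=C1/C(=C/c2ccc(Cl)cc2)CCC/C1=C\c1ccc([N+](=O)[O-])cc1` and compound 3 `O=C1/C(=C/c2ccc(Cl)cc2)CCC/C1=C\c1cccc([N+](=O)[O-])c1` carry the same groups; how the two cores differ is not broken down here. In a functional assay on L1210 cells (Mus musculus) for cytotoxicity, with a stated time of 48 h (on this read-out higher numbers stand for weaker inhibition and lower numbers for stronger inhibition), compound 1 gives 9410 nM. In this assay compound 3 gives 9160 nM, and these two values sit within the usual scatter of each other, so neither can be called the stronger. Compound 2 `CN(C)c1ccc(/C=C2\CCC/C(=C\c3ccc([N+](=O)[O-])cc3)C2=O)cc1` arises from compound 1 by dimethylamino in place of chloro on an aromatic carbon. For compound 2 this assay reports only a limit, > 500000 nM, and not a number. The step of an at least 53-fold higher number from compound 1 to compound 2 (1.72 log units; beyond the scatter) can be read only as far as the limit of > 500000 nM in this assay, at which 1 of the 3 values shown sits, allows, so its true size may be larger still.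

Compound 4 `CN(C)c1ccc(/C=C2\CCC/C(=C\c3cccc([N+](=O)[O-])c3)C2=O)cc1` has not yet been measured. Among the compounds with values here, it arises from compound 3 by dimethylamino in place of chloro on an aromatic carbon, the same change as the one from compound 1 to compound 2, made at a place described in the same words. The expectation for compound 4 rests on compound 1 at 9410 nM and compound 3 at 9160 nM sitting within scatter of each other, and on the earlier step of an at least 53-fold higher number from compound 1 to compound 2 (1.72 log units; beyond the scatter). A step of like large size is expected in this assay, namely a 55-fold higher number from compound 3 to compound 4 (1.74 log units; beyond the scatter). Compound 4 is therefore estimated at 500000 nM, with the likely outcome being a limit rather than a number, and the range of expectation running from 150000 nM to 1500000 nM.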

Compound 4, half-maximal inhibitory concentration: 156000 nM
For compound 4 the middle estimate is 3.2-fold (0.51 log units) above the measured one; measured number inside the range.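

In this assay the change from chloro to dimethylamino weakens inhibition on the second core as well, with a 17-fold higher number from compound 3 to compound 4 (1.23 log units; beyond the scatter), and with dimethylamino in place the 3-nitrophenyl compound also stands apart from the 4-nitrophenyl one, with an at least 3.2-fold lower number from compound 2 to compound 4 (0.50 log units; beyond the scatter). So the direction of the change carries from one core to the other, but its size does not carry over unchanged: the same change on two cores in this assay, an at least 53-fold higher number (1.72 log units; beyond the scatter) from compound 1 to compound 2 and a 17-fold higher number (1.23 log units; beyond the scatter) from compound 3 to compound 4, at least 3.1-fold (0.49 log units) apart, beyond the scatter of two such steps. Compound 2 is the compound held at a limit, so the gap between the two steps is only a lower bound, its true size may be larger, and these values do not show what lies behind it: the limit of > 500000 nM in this assay, at which 1 of the 4 values shown sits.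

Within the data shown here, with only chloro and dimethylamino compared, and on only two cores, it stays open whether a group such as methoxy, fluoro or diethylamino at the same place would follow the same direction or show the same dependence on the core. Going by these compounds, it also stays open whether a measured number for compound 2, or results from a second kind of cell, would keep the two steps as far apart as they appear here.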